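The source may hold more compounds than are shown below. What is called first, only, known or untested is meant among the compounds shown, and "the series" means these compounds.

Working notes on the series.

Compound 1 `C[C@@H]1O[C@H](CCC=C(Br)Br)C([Si](C)(C)C)=C(Cl)[C@H]1C` and compound 2 `C#CCC[C@H]1O[C@@H](C)[C@H](C)C(Cl)=C1[Si](C)(C)C` share one core, compound 3 `ClC1=CC(CCC=C(Br)Br)OCC1` has another; the difference between the two cores is not broken down here. In a functional assay on SW1573 cells (Homo sapiens) for antiproliferative activity (on this read-out higher numbers stand for weaker inhibition of growth and lower numbers for stronger inhibition of growth), compound 1 gives 22000 nM, and compound 2 gives 19000 nM. Compound 2 differs from compound 1 by ethynyl in place of 2,2-dibromoethenyl on a saturated chain carbon, two bonds along the chain from a saturated ring carbon; this gave a 1.2-fold lower number from compound 1 to compound 2 (0.06 log units; within the scatter). In this assay compound 3 gives 30000 nM, a value within the scatter of both compound 1 and compound 2.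

Compound 4 `C#CCCC1C=C(Cl)CCO1` is not yet measured. It differs from compound 3 by ethynyl in place of 2,2-dibromoethenyl on a saturated chain carbon, two bonds along the chain from a saturated ring carbon. The place lines of the two changes read the same word for word, so this is the same change already seen from compound 1 to compound 2, now on the core of compound 3.

Within the data shown here, the expected step from compound 3 to compound 4 is a 1.2-fold lower number from compound 3 to compound 4 (0.08 log units; within the scatter), a size resting on the one earlier instance, where the change gave a 1.2-fold lower number from compound 1 to compound 2 (0.06 log units; within the scatter) and stayed within the scatter. Compound 4 is therefore expected to give 25000 nM, with a range from 12000 nM to 50000 nM.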

Compound 4, concentration for 50% growth inhibition: 41000 nM
Compound 4: the middle estimate sits 1.6-fold (0.21 log units) below what was measured; the range from low to high includes it.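

In this assay, ethynyl in place of 2,2-dibromoethenyl gives a 1.4-fold higher number from compound 3 to compound 4 (0.14 log units; within the scatter), so on the core of compound 3 the change again leaves the number within the scatter. Set beside the earlier instance, the two steps cannot be told apart, and the change carries from one core to the other with no difference that can be read: the same change on two cores in this assay, a 1.2-fold lower number (0.06 log units; within the scatter) from compound 1 to compound 2 and a 1.4-fold higher number (0.14 log units; within the scatter) from compound 3 to compound 4, 1.6-fold (0.20 log units) apart, within the scatter of two such steps. This does not show that the change has a defined size or direction, since neither step rises above the scatter, and two cores say nothing about how the change behaves on any other core in the series.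

The compounds shown leave open whether any group in this place moves the number beyond the scatter, for instance an amine, a carboxylic acid or a longer chain in place of ethynyl. Among these compounds, they also leave open which part of the difference between the two cores matters in this read-out, as no pair separates the trimethylsilyl or methyl groups of compound 1 from the rest of its core.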